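The source may report more compounds than this note shows. Statements on the series, on what has been measured and on what is new or still open speak of the compounds shown alone.

Compound 1 `NC(=O)c1c(NC(=O)c2cnn3c(C(F)(F)F)cc(-c4ccccc4)nc23)sc2c1CCCC2` and compound 2 `Cc1ccc(-c2cc(C(F)(F)F)n3ncc(C(=O)Nc4sc5c(c4C(N)=O)CCCC5)c3n2)cc1` share one core and differ only in methyl in place of hydrogen on an aromatic carbon. In an ADME assay on HEK-293T cells (Homo sapiens) for cytotoxicity, read by MTT assay, with a stated time of 24 h (on this read-out lower numbers stand for higher toxicity in this test and higher numbers for lower toxicity in this test), compound 1 gives > 250000 nM, which is a limit of the assay and not a number. In this assay compound 2 gives > 250000 nM, again a limit rather than a measured value. The step that the two limits leave unreadable from compound 1 to compound 2 cannot be read because both values sit at the limit of > 250000 nM in this assay, at which 2 of the 2 values shown sit. Compound 2 thus stands at the limit, and nothing shown sets it apart from compound 1.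

Compound 3 `COc1ccc(-c2cc(C(F)(F)F)n3ncc(C(=O)Nc4sc5c(c4C(N)=O)CCCC5)c3n2)cc1` carries the change (methoxy in place of methyl on an aromatic carbon). Within the data shown here, the only measured step that bears on it is a step that the two limits leave unreadable from compound 1 to compound 2, whose size the two limits hide. With both measured compounds resting at the limit, compound 3 is expected to behave alike, and the step that the limit leaves unreadable from compound 2 to compound 3 is expected to be none beyond the scatter. The value of compound 3 in this assay is therefore estimated at 300000 nM, within a range from 150000 nM to 1000000 nM, most likely reported once more as a limit.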

Compound 3, half-maximal cytotoxic concentration: 40400 nM
The estimate for compound 3 lay 7.4-fold (0.87 log units) above the measured number; measured number below the stated range.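

The position on the six-membered aromatic ring of carbon only, para to a large group, turns out not to be silent in this assay: methoxy in place of methyl gives an at least 6.1-fold lower number from compound 2 to compound 3 (0.79 log units; beyond the scatter), and methoxy in place of hydrogen gives an at least 6.1-fold lower number from compound 1 to compound 3 (0.79 log units; beyond the scatter). Of the three compounds, only compound 3, with its 4-methoxyphenyl group, gives a measured number rather than a limit, and on this read-out its lower number stands for higher toxicity in this test. Both steps give only a minimum size, and the step between compound 1 and compound 2 cannot be read: the limit of > 250000 nM in this assay, at which 2 of the 3 values shown sit.

The compounds shown leave open whether an ethoxy group, a hydroxyl group or an amine at this place would also bring the number down from the limit, or whether the change is particular to methoxy. They also leave open whether a carboxylic acid there would behave alike, and, with the shared core the same in all three, whether the step would hold on any other core.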